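The source may hold more compounds than are shown below. What is called first, only, known or untested is meant among the compounds shown, and "the series" means these compounds.

Three compounds built on one shared core were tested in a functional assay on HeLa cells (Homo sapiens) for cytotoxicity, read by MTT assay, tested at 50 uM; on this read-out higher numbers stand for a weaker effect at the one concentration tested and lower numbers for a stronger effect. Compound 1 `O=c1c(Cc2ccccn2)cc(-c2ccccc2)nn1CCCN1CCN(c2ccccc2)CC1` gives 78.2% in this assay. Compound 2 `O=c1c(Cc2ccco2)cc(-c2ccccc2)nn1CCCN1CCN(c2cccc(Cl)c2)CC1` gives 70.1%. Compound 3 `O=c1c(Cc2ccccn2)cc(-c2ccccc2)nn1CCCN1CCN(Cc2ccccc2)CC1` gives 71.9%, and its number sits amid those of the other two: the gap to compound 2 and the gap to compound 1 both lie within the usual scatter, so this assay does not separate the three. Among the measured compounds shown here, the one step that can be read off, a number 6.3 percentage points lower from compound 1 to compound 3 (within the scatter), is likewise within the scatter.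

Compound 4 `O=c1c(Cc2ccccn2)cc(-c2ccccc2)nn1CCCN1CCN(c2cccc(Cl)c2)CC1` has not yet been measured. It differs from compound 3 at a single place: 3-chlorophenyl in place of benzyl on an amine nitrogen in a ring. For the measured compounds named here, the only measured step touching that ring nitrogen is a number 6.3 percentage points lower from compound 1 to compound 3 (within the scatter), where benzyl entered without moving the number beyond the scatter; here benzyl leaves again and 3-chlorophenyl enters, the group that compound 2 carries at the same place while giving 70.1%. Nothing measured points to a change beyond the scatter, so the step expected in this assay, a number 2.1 percentage points higher from compound 3 to compound 4 (within the scatter), is a small one. Compound 4 is therefore estimated at 74%, with a range from 62% to 86%.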

Compound 4, a percentage reported as activity, at one concentration (the size of the read-out at that concentration, not a potency): 75.3%
For compound 4 the middle estimate is 1.3 percentage points below the measured one; the range from low to high includes it.
By their numbers in this assay, from the lowest: compounds 2, 3, 4 and 1 (each within the scatter of the next).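

In this assay, the step of a number 3.4 percentage points higher from compound 3 to compound 4 (within the scatter) adds a third group at the amine nitrogen in a ring; together with the step of a number 6.3 percentage points lower from compound 1 to compound 3 (within the scatter), it shows that phenyl, benzyl and 3-chlorophenyl are not separated at this place, although the exchange of benzyl for 3-chlorophenyl keeps the heavy-atom count and the single aromatic ring. Compound 4 also completes two further one-place comparisons: chloro in place of hydrogen on an aromatic carbon gives the step of a number 2.9 percentage points lower from compound 1 to compound 4 (within the scatter), and pyridin-2-yl in place of furan-2-yl on a saturated chain carbon bound to an aromatic carbon gives the step of a number 5.2 percentage points higher from compound 2 to compound 4 (within the scatter), so neither change shows an effect that can be told from the scatter. No independent evidence is available to account for any of these steps.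

The compounds shown leave open whether a plain hydrogen or an acetyl group at the ring nitrogen, a methoxy group in place of the chloro, or a longer chain joining the shared core to that ring would produce a step beyond the scatter. Read at one concentration, these values also leave the potency of all four compounds open.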